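Iodo for thiophene on an inactive-looking nucleoside

The source may hold more compounds than are shown below. What is called first, only, known or untested is meant among the compounds shown, and "the series" means these compounds.

Measured so far in a functional assay on A549 cells (Homo sapiens), read by MTT assay, with a stated time of 72 h; on this read-out higher numbers stand for weaker inhibition and lower numbers for stronger inhibition:
Compound 1 `Nc1nc(N)c2c(-c3ccsc3)cn([C@@H]3O[C@H](CO)[C@@H](O)[C@H]3O)c2n1` gives > 100000 nM as a limit
Compound 2 `Cc1nc(N)c2c(-c3ccco3)cn([C@@H]3O[C@H](CO)[C@@H](O)[C@H]3O)c2n1` gives > 20000 nM as a limit
Compound 3 `Cc1nc(N)c2c(-c3ccsc3)cn([C@@H]3O[C@H](CO)[C@@H](O)[C@H]3O)c2n1` gives > 20000 nM as a limit

All three results are limits and not numbers, so no order among the compounds can be read from them. Compound 3 stands at the limit of > 20000 nM in this assay, at which 2 of the 3 values shown sit, and nothing finer is known about it. Compound 1 sits at the limit of > 100000 nM in this assay, at which 1 of the 3 values shown sits, and that also gives no ranking.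

The next compound is compound 4 `Cc1nc(N)c2c(I)cn([C@@H]3O[C@H](CO)[C@@H](O)[C@H]3O)c2n1` and it differs from compound 3 by iodo in place of thiophen-3-yl on an aromatic carbon with iodo in place of thiophen-3-yl on an aromatic carbon. Among the measured compounds shown here, two measured steps bear on this change. For the measured compounds named here, the one that swaps the group at this same place is a step that the two limits leave unreadable from compound 2 to compound 3 and it gives no size. The other, at a different place, is a step that the two limits leave unreadable from compound 1 to compound 3 and it gives no size either. Going by the values given here, no measured compound carries iodo, so neither a size nor a direction can be carried over. The expectation therefore rests on compound 3 alone, whose > 20000 nM is a limit. The estimated change is a step that the limit leaves unreadable from compound 3 to compound 4 and it has no firm direction. Compound 4 is expected at 25000 nM with an estimated range from 6000 nM to 100000 nM and it may well return only a limit.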

Compound 4, half-maximal inhibitory concentration: 12100 nM
Estimate against measurement, compound 4: 2.1-fold (0.32 log units) above; the measured number falls inside the stated range.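

Among the compounds shown here, compound 4 is the first compound here to give an actual number in this assay, so the place that carried thiophen-3-yl or furan-2-yl can hold a single iodo, with no ring at all, and still yield a readable inhibition of these cells. Replacing thiophen-3-yl with iodo gives an at least 1.6-fold lower number from compound 3 to compound 4 (0.21 log units; that floor lies within the scatter), and replacing furan-2-yl with iodo gives an at least 1.6-fold lower number from compound 2 to compound 4 (0.21 log units; that floor lies within the scatter). From the compounds shown here alone, each step is only a floor, and its true size stays unknown because compound 3 has a limit and not a number: the limit of > 20000 nM in this assay, at which 2 of the 4 values shown sit.

The compounds shown leave open whether iodo itself matters at this place, or whether bromo, chloro or a small amine on the same aromatic carbon would read the same way. They also leave open how amino in place of methyl would read with iodo present, since compound 1, the one compound shown with that amino group, carries thiophen-3-yl.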